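Compound 4: 3-cyanophenyl in place of ethyl

The source may report more compounds than this note shows. Statements on the series, on what has been measured and on what is new or still open speak of the compounds shown alone.

Values in a functional assay on U-373MG ATCC cells (Homo sapiens) for inhibition, read by MTT assay, with a stated time of 72 h (on this read-out lower numbers stand for stronger inhibition and higher numbers for weaker inhibition), are these:
- compound 1 `CCNC(=S)NC1CC(C)(C)Oc2ccc(Cl)cc21` gives 96000 nM as a number
- compound 2 `CC(=O)NC1CC(C)(C)Oc2ccc(Cl)cc21` gives > 100000 nM as a limit
- compound 3 `CCNC(=O)NC1CC(C)(C)Oc2ccc(Cl)cc21` gives > 100000 nM as a limit

Only compound 1 gives a number on this scale. The other two stand at the limit of > 100000 nM in this assay, at which 2 of the 3 values shown sit, as their result.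

Compound 4 `CC1(C)CC(NC(=S)Nc2cccc(C#N)c2)c2cc(Cl)ccc2O1` keeps the core of compound 1 and its thiocarbonyl, with 3-cyanophenyl in place of ethyl on an amide-type nitrogen as the change: 3-cyanophenyl in place of ethyl on an amide-type nitrogen.

The measured steps of an at least 1.0-fold higher number from compound 1 to compound 2 (0.01 log units; that floor lies within the scatter) and an at least 1.0-fold higher number from compound 1 to compound 3 (0.01 log units; that floor lies within the scatter) are floors only and alter the thiocarbonyl part. Neither brings in an aromatic ring, so neither gives a size for this change.

With compound 1 at 96000 nM as the sole anchor, a modest move to a lower number is expected, estimated as a 2.7-fold lower number from compound 1 to compound 4 (0.44 log units; beyond the scatter) in this assay on the structural change alone.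

Compound 4 is expected at 35000 nM with an estimated range from 9000 nM to 100000 nM in this read-out.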

Compound 4, half-maximal inhibitory concentration: 7000 nM
Compound 4: middle estimate off by 5.0-fold (0.70 log units), on the high side; measured number below the stated range.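

In this assay, the amide-type nitrogen bearing the thiocarbonyl carbon accepts an aromatic ring, and 3-cyanophenyl in place of ethyl gives a 14-fold lower number from compound 1 to compound 4 (1.14 log units; beyond the scatter). Among the compounds shown here, this is the first step whose size can be read, as the earlier steps cannot be read for size. Most earlier values gave no number on the scale: the limit of > 100000 nM in this assay, at which 2 of the 4 values shown sit.

Going by these compounds, whether the gain comes from the ring or the nitrile stays open, and an unsubstituted phenyl would separate the two. On these data alone, whether a carbonyl in place of the thiocarbonyl would keep the gain with 3-cyanophenyl also stays open.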